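The source may hold more compounds than are shown below. What is called first, only, known or untested is meant among the compounds shown, and "the series" means these compounds.

Working notes on the series.

Compound 1 `Cc1cc(-c2ccccc2)n(/C(N)=N/S(=O)(=O)c2cc(C)c(Cl)cc2SCc2ccccc2C)n1` gives 80000 nM in a functional assay on MCF7 cells (Homo sapiens) for cytotoxicity, read by MTT assay, with a stated time of 72 h (a higher number here means a weaker inhibitor, a lower number a stronger inhibitor), the highest number of the three measured compounds. Compound 2 `Cc1cc(S(=O)(=O)/N=C(\N)n2nccc2-c2ccccc2)c(SCc2ccccc2C)cc1Cl` gives 23000 nM in this assay, and the step of a 3.5-fold lower number from compound 1 to compound 2 (0.54 log units; beyond the scatter) lies beyond the scatter. Compound 3 `Cc1ccc(CSc2cc(Cl)c(C)cc2S(=O)(=O)/N=C(\N)n2nccc2-c2ccccc2)cc1` gives 21000 nM, so the step of a 1.1-fold lower number from compound 2 to compound 3 (0.04 log units; within the scatter) stays within the scatter; this step exchanges the 2-methylphenyl for a 4-methylphenyl on the saturated chain carbon bound to a sulfur, leaving the rest of the shared core untouched.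

Compound 4 `Cc1cc(-c2ccccc2)n(/C(N)=N/S(=O)(=O)c2cc(C)c(Cl)cc2SCc2ccc(Cl)cc2)n1` is not yet measured. It differs from compound 1 in one place: 4-chlorophenyl in place of 2-methylphenyl on a saturated chain carbon bound to a sulfur. Among the compounds with values here, the only measured step that bears on this change is the one from compound 2 to compound 3, which also alters the ring on the saturated chain carbon bound to a sulfur and which moved the number by no more than the scatter. Within the data shown here, no measured pair shows the effect of a 4-chlorophenyl at this place, so the expectation rests on that single step. A step of no more than the scatter is therefore expected in this assay, with direction undetermined.

Compound 4 is estimated at 70000 nM, within the range 30000 nM to 160000 nM, which corresponds to an expected step of a 1.1-fold lower number from compound 1 to compound 4 (0.06 log units; within the scatter).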

Compound 4, half-maximal inhibitory concentration: 108000 nM
Compound 4: the middle estimate sits 1.5-fold (0.19 log units) below what was measured, within the range that was stated.
By their numbers in this assay, from the lowest: compounds 3 and 2 (each within the scatter of the next); then compounds 1 and 4 (each within the scatter of the next).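

In this assay, the step of a 1.4-fold higher number from compound 1 to compound 4 (0.13 log units; within the scatter) shows that this place on the saturated chain carbon bound to a sulfur tolerates a chlorine-bearing ring as well as a methyl-bearing one, since 4-chlorophenyl in place of 2-methylphenyl gives no difference beyond the scatter. Within the data shown here, until now, the only reading at this place was the exchange of 2-methylphenyl for 4-methylphenyl, a 1.1-fold lower number from compound 2 to compound 3 (0.04 log units; within the scatter), so a second ring exchange, with a different group on the ring and on the methyl-bearing core of compound 1, now gives the same outcome, while a 3.5-fold lower number from compound 1 to compound 2 (0.54 log units; beyond the scatter), at the aromatic carbon that carries hydrogen in place of methyl, remains the only step here beyond the scatter. No measurement on hand gives an account of why these ring exchanges leave the number within the scatter.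

The compounds shown leave open whether a ring carrying an amine or a carboxylic acid, or a longer chain in place of 2-methylbenzyl, would give a step beyond the scatter at this place. They also leave open how 4-chlorophenyl reads on the core of compound 2.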